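The compounds below may be only part of what the source reports. "The series", "measured", "known", "first", "only" and "open" are said of these compounds alone.

Working notes on the series. Three compounds have numbers in a functional assay on Ramos cells (Homo sapiens) for antiproliferative activity, read by CCK-8 assay, with a stated time of 72 h, tested at 40 uM; on this read-out higher numbers stand for more inhibition at the one concentration tested (going by the name of the read-out) and lower numbers for less inhibition. Compound 1 `CCOC(=O)c1sc(-c2cccc(NC(=O)c3ccc(C(C)(C)C)cc3)c2)nc1Nc1ccc(N2CCN(C)CC2)cc1` gives 21.2%, compound 2 `CCOC(=O)c1sc(-c2cccc(NC(=O)c3ccc(Cl)cc3)c2)nc1Nc1ccc(N2CCN(C)CC2)cc1` gives 46.9%, and compound 3 `CN1CCN(c2ccc(Nc3nc(-c4cccc(NC(=O)c5ccc(C(C)(C)C)cc5)c4)sc3C(N)=O)cc2)CC1` gives 80.1%. Compound 3 stands highest of the three, with compound 2 nearest and compound 1 furthest, both differences beyond the scatter. The step of a number 58.9 percentage points higher from compound 1 to compound 3 (beyond the scatter) is the large one here; the step of a number 25.7 percentage points higher from compound 1 to compound 2 (beyond the scatter) is modest.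

Compound 4 `CN1CCN(c2ccc(Nc3nc(-c4cccc(NC(=O)c5ccc(Cl)cc5)c4)sc3C(N)=O)cc2)CC1` has not yet been measured. It differs from compound 3 in one place: chloro in place of tert-butyl on an aromatic carbon. The same exchange has already been seen once, in the ester pair, where the step of a number 25.7 percentage points higher from compound 1 to compound 2 (beyond the scatter) was a rise beyond the scatter. That step is the only measured one bearing on this change, so compound 4 is expected to sit at or above compound 3 in this assay. Because compound 3 already gives 80.1%, a rise of the earlier size is not expected, and a smaller step, possibly within the scatter, is expected instead: a number 7.9 percentage points higher from compound 3 to compound 4 (within the scatter). On that basis compound 4 is estimated at 88% in this assay, with a range from 74% to 97%.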

Compound 4, a percentage reported as inhibition, at one concentration (the size of the read-out at that concentration, not a potency): 99%
Estimate against measurement, compound 4: 11 percentage points below; measured number outside the range, above it.
By their numbers in this assay, from the lowest: compound 1; then compound 2; then compound 3; then compound 4.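

The exchange of tert-butyl for chloro, on an aromatic carbon para to a large group, also raises the number on the core of compound 3, a number 18.9 percentage points higher from compound 3 to compound 4 (beyond the scatter), so the rise is no longer confined to the ester pair, and in this assay the two steps agree: the same change on two cores in this assay, a number 25.7 percentage points higher (beyond the scatter) from compound 1 to compound 2 and a number 18.9 percentage points higher (beyond the scatter) from compound 3 to compound 4, 6.8 percentage points apart, within the scatter of two such steps

The exchange of amino for ethoxy on the carbonyl carbon, until now seen only with tert-butyl present, holds with chloro present, a number 52.1 percentage points higher from compound 2 to compound 4 (beyond the scatter), and again the two steps agree: the same change on two cores in this assay, a number 58.9 percentage points higher (beyond the scatter) from compound 1 to compound 3 and a number 52.1 percentage points higher (beyond the scatter) from compound 2 to compound 4, 6.8 percentage points apart, within the scatter of two such steps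

Across these four compounds the two exchanges therefore read as roughly additive, the size of each step showing no clear dependence on the group at the other place, and none of the four goes against this.

From the compounds shown here alone, whether the same holds for a fluoro or methoxy group on the aromatic carbon, or for a methylamino group or a hydroxyl on the carbonyl carbon, stays open. With compound 4 at 99%, this single-concentration read-out has little room left at the top and gives no potency, so a ranking of compounds at that level would need a full concentration series.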